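The source may report more compounds than this note shows. Statements on the series, on what has been measured and on what is new or still open speak of the compounds shown alone.

Measured so far, in a functional assay on HCT-116 cells (Homo sapiens) for inhibition, read by sulforhodamine B assay, with a stated time of 72 h; a lower number here means a stronger inhibitor, a higher number a weaker inhibitor:

compound 1 `CC(c1ccc(-c2ccccc2)c(F)c1)c1nnc2n1N=C(c1ccc(OC(F)(F)F)cc1)CS2`: 5400 nM
compound 2 `CC(c1ccc(-c2ccccc2)c(F)c1)c1n[nH]c(=S)n1N`: "not active" (no number reported)
compound 3 `COc1ccc2cc(C(C)c3n[nH]c(=S)n3N)ccc2c1`: 20200 nM

Compound 1 holds the lowest of the two numbers in this assay. Compound 3 sits above it by a gap beyond the usual scatter, and compound 2 has no number in this assay at all, so compound 1 is the reference point for the next step. Compounds 1 and 3 differ in more than one place, so their gap is not broken down into single changes; only the two values themselves are known.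

Compound 4 `CC(c1ccc(-c2ccccc2)c(F)c1)c1nnc2n1N=C(c1ccc(Cl)cc1)CS2` is the next compound to be measured. It differs from compound 1 in one place: chloro in place of trifluoromethoxy on an aromatic carbon. Within the data shown here, no pair of measured compounds shows this change, so nothing in the data gives its size or direction. In the absence of such a precedent the step from compound 1 to compound 4 is expected to be small, a 1.1-fold higher number from compound 1 to compound 4 (0.05 log units; within the scatter), with no clear direction beyond the scatter. For compound 4 the estimate in this assay is therefore 6000 nM, with a range from 2500 nM to 15000 nM.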

Compound 4, half-maximal inhibitory concentration: 7800 nM
For compound 4 the middle estimate is 1.3-fold (0.11 log units) below the measured one; the measured number falls inside the stated range.
By their numbers in this assay, from the lowest: compounds 1 and 4 (each within the scatter of the next); then compound 3.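

Among these compounds, the exchange of 4-(trifluoromethoxy)phenyl for 4-chlorophenyl gives the first single-place step in this assay, with a 1.4-fold higher number from compound 1 to compound 4 (0.16 log units; within the scatter) as its size. At this position, on an aromatic carbon para to a large group, this assay does not separate chloro from trifluoromethoxy, even though the heavy-atom count of the group goes from 5 to 1 and its hydrogen-bond acceptor is gone. No measurement at hand offers an explanation for this result.

As far as these compounds go, whether an amine, a carboxylic acid or a longer alkoxy chain at this position would give a step beyond the scatter remains open. Also open, from the compounds shown here alone, is how the same exchange would read on a core other than that of compound 1.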